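Trifluoromethyl for methyl on an inactive starting point

The source may hold more compounds than are shown below. What is called first, only, known or untested is meant among the compounds shown, and "the series" means these compounds.

Compound 2, `COc1cccc(/C=N/NC(=O)COc2ccc(Cl)cc2C)c1`, gives no single number in an ADME assay on cells for inhibition of anoctamin-2 (Homo sapiens), read by fluorescence, with a stated time of 20 min; a lower number here means a stronger inhibitor, a higher number a weaker inhibitor; for compound 2 the result is reported only as "not active" (no number reported). The one other result shown comes from compound 1, `COc1ccccc1-c1nnc(-c2cc3cc(Cl)ccc3o2)o1`, and is a limit of the assay rather than a measured number: compound 1 gives > 100000 nM. Among the compounds with values here, both values shown therefore sit at or past (the limit of > 100000 nM in this assay, at which 1 of the 2 values shown sits), so nothing measured so far points to a strong inhibitor.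

Compound 3, `Cc1cc(Cl)ccc1OCC(=O)N/N=C/c1cccc(OC(F)(F)F)c1`, has not been measured. It differs from compound 2 in one place: trifluoromethyl in place of methyl on an oxygen on an aromatic ring. Within the data shown here, no pair of measured compounds shares this change, so no measured step shows how large its effect could be. With one reading reported as inactive and the other a limit, reaching a clearly measured inhibition would need a large step, and the data give no ground to expect one.

Compound 3 is therefore expected to give about 100000 nM in this assay, with a likely range from 20000 nM to 300000 nM, and most probably a limit rather than a number.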

Compound 3, half-maximal inhibitory concentration: "not active" (no number reported)
No number was reported for compound 3; there is nothing to compare the estimate with.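

Compound 2 and compound 3 are both reported only as "not active", without a number, so no step can be read for the change from methoxy to trifluoromethoxy. The compounds shown leave open whether trifluoromethyl in place of methyl has any effect at all in this assay, and what structure would give a measurable inhibition there.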